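Amide Side Chain Shortened to Cyclopropyl at Histamine H3

The source may report more compounds than this note shows. Statements on the series, on what has been measured and on what is new or still open speak of the compounds shown alone.

Measured compounds:
compound 1 `Cc1cc(NC(=O)C2C(C)(C)C2(C)C)ccc1N1CCC(N2CCCC2C)C1`: 65.5 nM
compound 2 `Cc1cc(NC(=O)CC2CCCC2)ccc1N1CCC(N2CCCC2C)C1`: 10.7 nM

Within the data shown here, in an assay on CHO cells for displacement of a labelled ligand from histamine receptor H3 (Macaca mulatta) (on this read-out higher numbers stand for weaker inhibition and lower numbers for stronger inhibition), compound 2 gives the lower of the two numbers measured so far, with compound 1 as its only neighbour; the step of a 6.1-fold lower number from compound 1 to compound 2 (0.79 log units; beyond the scatter) separates them. Compound 3 `Cc1cc(NC(=O)C2CC2)ccc1N1CCC(N2CCCC2C)C1` is not yet measured. It differs from compound 2 in a single place: cyclopropyl in place of cyclopentylmethyl on a carbonyl carbon. Among the measured compounds shown here, the one measured step, from compound 1 to compound 2, concerns the same carbonyl carbon but compares a differently substituted three-membered ring with the cyclopentylmethyl group, so it bears on this change only loosely; it does show that the group on this carbonyl carbon can move the number by a modest but real amount. Nothing measured shows what the unsubstituted cyclopropyl does here. Compound 3 is therefore expected to come out near compound 2, with a step of a 1.9-fold higher number from compound 2 to compound 3 (0.27 log units; within the scatter) that may stay within the scatter. The estimate for compound 3 in this assay is 20 nM, with a range from 6 nM to 70 nM.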

Compound 3, inhibition constant: 17.7 nM
For compound 3 the middle estimate is 1.1-fold (0.05 log units) above the measured one, and the stated range covers the measured number.
By their numbers in this assay, from the lowest: compounds 2 and 3 (each within the scatter of the next); then compound 1.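

In this assay, cyclopropyl in place of cyclopentylmethyl on the carbonyl carbon gives a 1.7-fold higher number from compound 2 to compound 3 (0.22 log units; within the scatter), so this read-out does not separate the two groups, even though the group that leaves has 6 heavy atoms and the one that enters has 3. Cyclopropyl in place of 2,2,3,3-tetramethylcyclopropyl gives a 3.7-fold lower number from compound 1 to compound 3 (0.57 log units; beyond the scatter), which shows that a three-membered ring on this carbonyl carbon does not by itself give the higher number seen for compound 1: among these three compounds, only the 2,2,3,3-tetramethylcyclopropyl group stands apart. Nothing available here gives a reason for either step.

Still open, from the compounds shown here alone, is whether a partly substituted ring, such as 2,2-dimethylcyclopropyl, would read like cyclopropyl or like 2,2,3,3-tetramethylcyclopropyl, which would help show how much substitution the ring can carry. All three groups shown are made of carbon only, so the compounds say nothing about how a group containing an amine or a carboxylic acid, or a longer open chain such as n-hexyl, would behave on the same carbonyl carbon.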